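From iodo to chloro in the series

The source may report more compounds than this note shows. Statements on the series, on what has been measured and on what is new or still open speak of the compounds shown alone.

Measured in a functional assay on PC-3 cells (Homo sapiens) for cytotoxicity, read by MTT assay, with a stated time of 72 h; on this read-out lower numbers stand for stronger inhibition and higher numbers for weaker inhibition:
- compound 1 `Cc1ccc(S(=O)(=O)n2cc(COC3=C/C(=N\c4ccc(I)cc4)c4ccccc4C3=O)nn2)cc1` gives > 16300 nM
- compound 2 `Cc1ccc(/N=C2\C=C(OCc3cn(S(=O)(=O)c4ccc(C)cc4)nn3)C(=O)c3ccccc32)cc1` gives 2650 nM
- compound 3 `Cc1ccc(S(=O)(=O)n2cc(COC3=C/C(=N\c4ccc(F)cc4)c4ccccc4C3=O)nn2)cc1` gives 2030 nM

Compound 1 is the weakest of the three and has only a limit, > 16300 nM.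

Compound 4 `Cc1ccc(S(=O)(=O)n2cc(COC3=C/C(=N\c4ccc(Cl)cc4)c4ccccc4C3=O)nn2)cc1` is unmeasured and differs from compound 1 by chloro in place of iodo on an aromatic carbon. For the measured compounds named here, two measured steps bear on it: an at least 8.0-fold lower number from compound 1 to compound 3 (0.90 log units; beyond the scatter) and an at least 6.1-fold lower number from compound 1 to compound 2 (0.78 log units; beyond the scatter), both beyond the scatter. Between the two replacements, a 1.3-fold lower number from compound 2 to compound 3 (0.12 log units; within the scatter) stays within the scatter. On these data alone, a similar move to a lower number is therefore expected in this assay, although chloro itself is untested. The expected step is an at least 5.4-fold lower number from compound 1 to compound 4 (0.73 log units; beyond the scatter). Compound 4 is estimated at 3000 nM, with an expected range of 1200 nM to 9000 nM.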

Compound 4, half-maximal inhibitory concentration: > 20000 nM
Compound 4: no number, only a limit (the forecaster's own chance of this, stated with the estimate: 10%); middle value at least 6.6-fold (0.82 log units) from the limit.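

In this assay, compound 4 gives a limit and not a number: the limit of > 20000 nM in this assay, at which 1 of the 4 values shown sits.

Chloro therefore parts from the other two replacements at this aromatic carbon, with an at least 9.8-fold higher number from compound 3 to compound 4 (0.99 log units; beyond the scatter) and an at least 7.5-fold higher number from compound 2 to compound 4 (0.87 log units; beyond the scatter). Among the compounds shown, only chloro and iodo end in limits, so a single halogen swap here can separate compounds clearly, and the step between compound 1 and compound 4 cannot be read.

On these data alone, how far either limit lies from a true value stays open. So does whether bromo, methoxy or an amine at this position would track fluoro and methyl or chloro and iodo.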